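The source may report more compounds than this note shows. Statements on the series, on what has been measured and on what is new or still open speak of the compounds shown alone.

Compound 1 `CCOC(=O)c1c(-c2cc3ccc(OC)cc3oc2=O)nn(-c2ccccc2)c1C(=O)OCC`: in a functional assay on A549 cells (Homo sapiens) for cytotoxicity, read by MTT assay, with a stated time of 48 h (on this read-out lower numbers stand for stronger inhibition and higher numbers for weaker inhibition), compound 1 gives 132000 nM.
Compound 2 `CCOC(=O)c1c(-c2cc3ccc(OC)cc3oc2=O)nn(-c2cccc(C)c2)c1C(=O)OCC`: in this assay compound 2 gives 171000 nM.

The two numbers lie together: the step from compound 1 to compound 2 is a 1.3-fold higher number from compound 1 to compound 2 (0.11 log units; within the scatter), so compound 2 stands beside compound 1 rather than apart from it. Compound 3 `CCOC(=O)c1c(-c2cc3ccc(OC)cc3oc2=O)nn(-c2cccc(Cl)c2)c1C(=O)OCC` differs from compound 2 by chloro in place of methyl on an aromatic carbon, at the same aromatic carbon that the methyl of compound 2 occupies. Going by the values given here, the only comparison bearing on this position, a 1.3-fold higher number from compound 1 to compound 2 (0.11 log units; within the scatter), was within the scatter, so for compound 3 no step beyond the scatter is expected in this assay. The estimated step of a 1.1-fold lower number from compound 2 to compound 3 (0.06 log units; within the scatter) places compound 3 at 150000 nM, expected between 70000 nM and 320000 nM.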

Compound 3, half-maximal inhibitory concentration: 221000 nM
Beside the measured number, compound 3's estimate is 1.5-fold (0.17 log units) below it; low and high end bracket the measured number.
By their numbers in this assay, from the lowest: compounds 1, 2 and 3 (each within the scatter of the next).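

With chloro, this aromatic carbon has now carried three different groups, and neither a 1.3-fold higher number from compound 2 to compound 3 (0.11 log units; within the scatter) nor a 1.7-fold higher number from compound 1 to compound 3 (0.22 log units; within the scatter) leaves the scatter in this assay. Hydrogen, methyl and chloro at this carbon therefore cannot be told apart on this read-out. No measurement at hand offers an explanation for how closely these numbers lie together. Going by these compounds, whether an amine, a carboxylic acid or a longer chain at this carbon would give a step beyond the scatter remains open. So does whether a change elsewhere on the shared core would do so.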